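The source may hold more compounds than are shown below. What is called first, only, known or untested is meant among the compounds shown, and "the series" means these compounds.

Two compounds of the series have numbers in an assay on a protein complex for inhibition of ubiquitin carboxyl-terminal hydrolase 1/WD repeat-containing protein 48 (Homo sapiens), read by fluorescence; a higher number here means a weaker inhibitor, a lower number a stronger inhibitor. Compound 1 `FC(F)(F)c1ccccc1-c1nc(NCc2ccc(-c3cccc(Cl)c3)cc2)c2ccccc2n1` gives 2700 nM. Compound 2 `CCc1ccccc1-c1nc(NCc2ccc(-c3cccnc3)cc2)c2ccccc2n1` gives 780 nM, the lowest of the two numbers; the number of compound 1 stands above it by a margin beyond the scatter. Compound 3 `c1cncc(-c2ccc(CNc3nc(-n4ccnc4)nc4ccccc34)cc2)c1` has not yet been measured in this assay. It differs from compound 2 in one place: 1H-imidazol-1-yl in place of 2-ethylphenyl on an aromatic carbon. For the measured compounds named here, no pair of measured compounds differing only here is on hand, so the size of the step from compound 2 to compound 3 rests on the change itself: a group of 5 heavy atoms in place of one of 8 on the core. A step toward a higher number, of moderate size and beyond the scatter, is expected, as a 2.1-fold higher number from compound 2 to compound 3 (0.31 log units; beyond the scatter). For compound 3 in this assay the estimate is 1600 nM, with a range from 400 nM to 6500 nM.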

Compound 3, half-maximal inhibitory concentration: "not active" (no number reported)
The entry for compound 3 holds no number, so the estimate cannot be set against anything.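

For the compounds shown here, compound 3 is entered as not active in this assay with no number, so no step from compound 2 to compound 3 can be read. The compounds shown leave open how far 1H-imidazol-1-yl in place of 2-ethylphenyl shifts the number. Nothing on hand bears on this result.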